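Ortho-substituted aryl returns at the chain carbon of compound 2

The compounds below may be only part of what the source reports. "The series", "measured", "known", "first", "only" and "open" are said of these compounds alone.

Compound 1 `O=C(O)c1ccccc1-c1ccc(CCc2ncc(Cc3ccccc3F)[nH]2)cc1` gives 177 nM in an in vitro functional assay on cells for agonist activity at Bombesin receptor subtype-3 (Homo sapiens), read by luminescence and calcium flux (a lower number here means that less compound is needed, a higher number that more compound is needed for the effect), and compound 2 `O=C(O)c1ccccc1-c1ccc(CCc2ncc(CCc3ccccc3)[nH]2)cc1` gives 1320 nM in the same assay. Within the data shown here, the single step between them, a 7.5-fold higher number from compound 1 to compound 2 (0.87 log units; beyond the scatter), is the only comparison available. Among the measured compounds shown here, compound 2 therefore carries the highest of the two numbers so far, with compound 1 as its only neighbour.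

Compound 3 `N#Cc1ccccc1Cc1cnc(CCc2ccc(-c3ccccc3C(=O)O)cc2)[nH]1` is the next point and has not yet been measured. It differs from compound 2 in one place: 2-cyanophenyl in place of benzyl on a saturated chain carbon bound to an aromatic carbon. This change runs in the opposite sense to the change from compound 1 to compound 2, which exchanged a 2-fluorophenyl for a benzyl at that same saturated chain carbon. For the measured compounds named here, because a 7.5-fold higher number from compound 1 to compound 2 (0.87 log units; beyond the scatter) was a modest but clear rise, the reverse kind of change, benzyl back to a 2-substituted phenyl, is expected to bring the number down again, though with only one step to lean on the size is uncertain. Compound 3 is thus expected to give about 300 nM in this assay, with a likely range from 100 nM to 1000 nM, an expected step of a 4.4-fold lower number from compound 2 to compound 3 (0.64 log units; beyond the scatter) from compound 2.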

Compound 3, half-maximal effective concentration: 5480 nM
Compound 3: middle estimate off by 18-fold (1.26 log units), on the low side; the measured number lies above the stated range.
By their numbers in this assay, from the lowest: compound 1; then compound 2; then compound 3.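

The position does not respond to a 2-substituted phenyl as a class: in this assay, 2-cyanophenyl in place of benzyl on a saturated chain carbon gives a 4.2-fold higher number from compound 2 to compound 3 (0.62 log units; beyond the scatter), so the return of such a ring does not bring the number back towards that of compound 1. Among these compounds, this step also reads as phenethyl to 2-cyanobenzyl, so it changes the chain and the ring substituent together, whereas the cleaner comparison is cyano in place of fluoro on an aromatic carbon, with a 31-fold higher number from compound 1 to compound 3 (1.49 log units; beyond the scatter), the largest step so far. Within this pair the choice of substituent matters strongly, though no measurement at hand accounts for the direction or size of the change.

The compounds shown leave open how a chloro or methoxy group at that aromatic carbon would stand against fluoro and cyano, and where an unsubstituted phenyl on the same saturated chain carbon would fall. They also leave open whether fluoro would still give the lower number than cyano on a phenethyl chain.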